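A few compounds are considered here, and "the series" means these few. Any claim that something is new, unique, unknown or untested is made for them only; others in the source may bear on it.

Of the compounds shown here, two have numbers so far in a functional assay on DU-145 cells (Homo sapiens) for cytotoxicity, read by MTT assay, with a stated time of 48 h; a higher number here means a weaker inhibitor, a lower number a stronger inhibitor. Here compound 1 `COc1ccc(-c2nc3ccccn3c2C(=O)/C=C\Nc2cc(OC)cc(OC)c2)cc1` gives 6260 nM, and compound 2 `COc1cc(N/C=C\C(=O)c2c(-c3ccc(Cl)cc3)nc3ccccn23)cc(OC)c1OC` gives 3250 nM. These two values lie within the usual scatter of repeated measurements, so compound 2 cannot be ranked apart from compound 1.

Compound 3 `COc1cc(N/C=C\C(=O)c2c(-c3ccc(Cl)cc3)nc3ccccn23)cc(OC)c1` comes from compound 2 through one small edit: hydrogen in place of methoxy on an aromatic carbon. Hydrogen stands in place of methoxy on an aromatic carbon, at a spot ortho to two methoxy groups and para to a large group. The rest of the structure stays the same.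

Within the data shown here, no measured pair shows this exchange on its own, so any forecast is loose. With so little to go on, the expectation is a small step toward a higher number in this assay, meaning a slightly weaker inhibitor, and it may not clear the scatter at all. In numbers, the estimate means a 1.4-fold higher number from compound 2 to compound 3 (0.14 log units; within the scatter). For compound 3 the expected value is 4500 nM, with an estimated range from 1500 nM to 13000 nM.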

Compound 3, half-maximal inhibitory concentration: 12000 nM
Beside the measured number, compound 3's estimate is 2.7-fold (0.43 log units) below it, and the stated range covers the measured number.
By their numbers in this assay, from the lowest: compounds 2, 1 and 3 (each within the scatter of the next, the first and the last beyond it).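

In this assay, hydrogen in place of methoxy on an aromatic carbon gives a 3.7-fold higher number from compound 2 to compound 3 (0.57 log units; beyond the scatter), the first single edit here whose size clears the usual scatter. It shows that, at this spot ortho to two methoxy groups and para to a large group, the methoxy group goes with the lower number, at least with chloro on the other aromatic ring. The second edit, chloro in place of methoxy on an aromatic carbon, gives a 1.9-fold higher number from compound 1 to compound 3 (0.28 log units; within the scatter) and so cannot be ranked, and no measurement at hand bears on why the first edit moves the number as it does.

One open question is whether methoxy itself matters at this spot or whether other groups would serve as well, such as a hydroxyl group, a fluorine atom or an ethoxy group. Also open, from the compounds shown here alone, is whether losing the methoxy group would cost as much with a group other than chloro on the other ring, since this reading rests on one pair of compounds.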